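The compounds below may be only part of what the source reports. "The series", "measured", "known", "first", "only" and "open" are said of these compounds alone.

Compound 1 `COc1cc(-c2nnc(SCC(=O)Nc3ccc(/C(C)=N/O)cc3)n2-c2ccccc2)cc(OC)c1OC` and compound 3 `COc1ccc(-c2nnc(SCC(=O)Nc3ccc(/C(C)=N/O)cc3)n2-c2ccccc2)cc1OC` share one core, while compound 2 `CCn1c(SCC(=O)Nc2ccc(C(C)=O)cc2)nnc1-c1ccc(OC)c(OC)c1` rests on another; how the two cores differ is not broken down here. In a functional assay on the whole organism (strain albino) for inhibition, with Rattus norvegicus as the target, read by paw edema, with stated times of 30 min and 2 h, at a dose of 0.28 mmol/kg by the oral route (on this read-out higher numbers stand for more inhibition at the one dose given (going by the name of the read-out) and lower numbers for less inhibition), compound 1 gives 62% and compound 3 gives 63%, a step of a number 1 percentage points higher from compound 1 to compound 3 (within the scatter) brought about by hydrogen in place of methoxy on an aromatic carbon. In this assay compound 2 gives 59%. Compound 4 `CCn1c(SCC(=O)Nc2ccc(C(C)=O)cc2)nnc1-c1ccc(OC)cc1` has not yet been measured; it arises from compound 2 by hydrogen in place of methoxy on an aromatic carbon. This is the same kind of change as that from compound 1 to compound 3, not the same, since the earlier place is also meta to a methoxy group. Because the step of a number 1 percentage points higher from compound 1 to compound 3 (within the scatter) lay within the scatter, the expected step is a number 1 percentage points higher from compound 2 to compound 4 (within the scatter). Compound 4 is therefore estimated at 60%, between 50% and 70%.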

Compound 4, a percentage reported as inhibition, in the whole organism at one dose (the size of the read-out at that dose, not a potency): 54%
Estimate against measurement, compound 4: 6 percentage points above; the measured number falls inside the stated range.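

In this assay, replacing 3,4-dimethoxyphenyl with 4-methoxyphenyl gave a number 5 percentage points lower from compound 2 to compound 4 (within the scatter). Set beside the earlier step, the change shows no difference that can be told apart between the two cores: the same change on two cores in this assay, a number 1 percentage points higher (within the scatter) from compound 1 to compound 3 and a number 5 percentage points lower (within the scatter) from compound 2 to compound 4, 6 percentage points apart, within the scatter of two such steps

This does not show that the two cores respond alike, or that the change does nothing on either of them: each core offers a single pair, and such small steps cannot settle the matter.

The compounds shown leave open whether another group in this place, such as a hydroxyl, an amine or a chlorine atom, would move the inhibition beyond the scatter. Going by these compounds, how the compounds compare at other doses also remains open.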